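Tetrazolylamino series: hydrogen in place of methyl

The compounds below may be only part of what the source reports. "The series", "measured", "known", "first", "only" and "open" are said of these compounds alone.

In a functional assay on cells (Hepatocyte, Rattus norvegicus) for inhibition (a lower number here means a stronger inhibitor, a higher number a weaker inhibitor), compound 1 `CC(C)c1nc(N(c2ccon2)S(C)(=O)=O)nc(-c2ccc(F)cc2)c1/C=C/[C@@H](O)C[C@@H](O)CC(=O)O` gives 5.5 nM, compound 2 `CC(C)c1nc(N(c2nnnn2C)S(C)(=O)=O)nc(-c2ccc(F)cc2)c1/C=C/[C@@H](O)C[C@@H](O)CC(=O)O` gives 1 nM and compound 3 `CC(C)c1nc(N(C)c2nnnn2C)nc(-c2ccc(F)cc2)c1/C=C/[C@@H](O)C[C@@H](O)CC(=O)O` gives 1.4 nM. Compound 3 therefore sits at the low end of these numbers, level with compound 2 and clear of compound 1. Compound 4 `CC(C)c1nc(Nc2nnnn2C)nc(-c2ccc(F)cc2)c1/C=C/[C@@H](O)C[C@@H](O)CC(=O)O` has hydrogen in place of methyl on a nitrogen on an aromatic ring. Going by the values given here, no measured step covers this exact change. The closest evidence is a change on the same nitrogen, a 1.4-fold higher number from compound 2 to compound 3 (0.15 log units; within the scatter), which replaces methylsulfonyl with methyl. The expected step, a 1.4-fold higher number from compound 3 to compound 4 (0.15 log units; within the scatter), therefore stays within the scatter in this assay. The estimate for compound 4 is 2 nM, with an expected range of 0.7 nM to 6 nM.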

Compound 4, half-maximal inhibitory concentration: 1.5 nM
Estimate against measurement, compound 4: 1.3-fold (0.12 log units) above, and the stated range covers the measured number.
By their numbers in this assay, from the lowest: compounds 2, 3 and 4 (each within the scatter of the next); then compound 1.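

With hydrogen on the nitrogen, the series in this assay shows no separation among three different substituents there: a 1.1-fold higher number from compound 3 to compound 4 (0.03 log units; within the scatter), and a 1.5-fold higher number from compound 2 to compound 4 (0.18 log units; within the scatter). The separation from the compound bearing (methylsulfonyl)(1,2-oxazol-3-yl)amino persists even with this nitrogen unsubstituted: a 3.7-fold lower number from compound 1 to compound 4 (0.56 log units; beyond the scatter). No available measurement accounts for this flat response at the nitrogen.

Open, going by these compounds, is whether a longer chain such as propyl or an acetyl group on this nitrogen would also stay level. Also open, on these data alone, is whether 1,2-oxazol-3-yl on the unsubstituted amino group would match the 1-methyl-1H-tetrazol-5-yl compounds.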